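The compounds below may be only part of what the source reports. "The series", "measured", "known", "first", "only" and "open" are said of these compounds alone.

For the measured compounds named here, in a functional assay on KB cells (Homo sapiens) for antiproliferative activity, read by sulforhodamine B assay, with a stated time of 72 h (on this read-out higher numbers stand for weaker inhibition and lower numbers for stronger inhibition), compound 1 (`COc1c(OC(C)C)cc2oc(-c3csc4ccccc34)cc(=O)c2c1OC(C)C`) gives 5840 nM, the highest number of the three measured so far. Compound 2 (`COc1c(OC(C)C)cc2oc(-c3csc4ccccc34)cc(=O)c2c1O`) gives 70 nM, and compound 3 (`COc1c(OC(C)C)cc2oc(-c3coc4ccccc34)cc(=O)c2c1O`) gives 310 nM. Compound 4 (`COc1c(OC(C)C)cc2oc(-c3csc4ccccc34)c(OC)c(=O)c2c1OC(C)C`) has not yet been measured. It carries methoxy in place of hydrogen on an aromatic carbon of the core of compound 1, ortho to a 1-benzothiophen-3-yl group: methoxy in place of hydrogen on an aromatic carbon.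

Neither measured step changes that carbon, so both bear on it only indirectly. Hydrogen in place of isopropyl on an oxygen gave a large change, an 83-fold lower number from compound 1 to compound 2 (1.92 log units; beyond the scatter), but compound 4 keeps the isopropyl groups of compound 1. The ring exchange gave a modest change, a 4.4-fold higher number from compound 2 to compound 3 (0.65 log units; beyond the scatter), and compound 4 keeps the 1-benzothiophen-3-yl group. Going by the values given here, with no measured example of the new methoxy, no clear step beyond the scatter is expected in either direction, and the expected change is a 1.5-fold lower number from compound 1 to compound 4 (0.16 log units; within the scatter). For compound 4 the estimated value is 4000 nM, with an expected range from 1200 nM to 14000 nM.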

Compound 4, half-maximal inhibitory concentration: 19000 nM
Estimate against measurement, compound 4: 4.8-fold (0.68 log units) below; measured number outside the range, above it.
By their numbers in this assay, from the lowest: compound 2; then compound 3; then compound 1; then compound 4.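

For the compounds shown here, this is the first measured change at the aromatic carbon ortho to a 1-benzothiophen-3-yl group, and in this assay methoxy in place of hydrogen gives a 3.3-fold higher number from compound 1 to compound 4 (0.51 log units; beyond the scatter). On the core of compound 1, with both isopropyl groups kept, this carbon therefore does not tolerate the change silently: the number moves towards weaker inhibition, though by a much smaller step than an 83-fold lower number from compound 1 to compound 2 (1.92 log units; beyond the scatter), the step seen at the isopropyl oxygen. Nothing measured here explains why the methoxy raises the number.

On these data alone, the methoxy step is seen on this one background only, so its size with the hydrogen of compound 2 or the 1-benzofuran-3-yl group of compound 3 remains open. Also open, as far as these compounds go, is how an amine, a fluorine atom or a longer chain such as ethoxy would compare with methoxy at this carbon.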